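The source may report more compounds than this note shows. Statements on the series, on what has been measured and on what is new or still open speak of the compounds shown alone.

In a functional assay on the whole organism (strain Wistar) with Rattus norvegicus as the target, with a stated time of 5 min (a lower number here means that less compound is needed, a higher number that more compound is needed for the effect), compound 1 `CC(C)CC1(CCCCN2CCN(c3cccc(Cl)c3)CC2)C(=O)Nc2ccccc21` gives 10 mg/kg. Compound 2 `CCC1(CCCCN2CCN(c3ccc(OC)cc3)CC2)C(=O)Nc2ccccc21` reaches only a limit of the assay, > 20 mg/kg. Compound 3 `CCC1(CCCCN2CCN(c3cccc(Cl)c3)CC2)C(=O)Nc2ccc(Cl)cc21` likewise stops at a limit, > 20 mg/kg. Compound 2 therefore stands at the limit of > 20 mg/kg in this assay, at which 2 of the 3 values shown sit, with no number of its own. Compound 4 `CCC1(CCCCN2CCN(c3ccccc3OC)CC2)C(=O)Nc2ccccc21` has not yet been measured; it differs from compound 2 by 2-methoxyphenyl in place of 4-methoxyphenyl on an amine nitrogen in a ring. Going by the values given here, no measured pair shows what such a change does, so the step in this assay is open; a small move in either direction, or none beyond the scatter, seems possible, and a limit again is the likeliest outcome. Compound 4 is expected to give about 25 mg/kg, between 10 mg/kg and 60 mg/kg. That would mean an expected step that the limit leaves unreadable from compound 2 to compound 4.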

Compound 4, minimum effective dose: 10 mg/kg
Compound 4: the middle estimate sits 2.5-fold (0.40 log units) above what was measured, and the stated range covers the measured number.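

With the same atoms joined differently, 2-methoxyphenyl in place of 4-methoxyphenyl on the amine nitrogen in the ring gives an at least 2.0-fold lower number from compound 2 to compound 4 (0.30 log units; that floor lies within the scatter) in this assay. The true step may be larger, since compound 2 has no number of its own: the limit of > 20 mg/kg in this assay, at which 2 of the 4 values shown sit.

Even so, this single change is enough to give compound 4 a measured dose rather than a limit. From the compounds shown here alone, whether a 2-ethoxyphenyl or 2-hydroxyphenyl group on this nitrogen would behave like 2-methoxyphenyl stays open.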